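The source may report more compounds than this note shows. Statements on the series, on what has been measured and on what is new or still open speak of the compounds shown alone.

- compound 1 `COc1cc(NCc2ccc(Cl)s2)ccc1-c1cnco1`: 53800 nM
- compound 2 `COc1cc(NCc2ccncc2)ccc1-c1cnco1`: 342000 nM

In an ADME assay on Vero cells (Chlorocebus sabaeus) for cytotoxicity, read by MTT assay, with a stated time of 96 h (on this read-out higher numbers stand for lower toxicity in this test and lower numbers for higher toxicity in this test), compound 2 has the higher of the two numbers, 342000 nM. Compound 3 `COc1cc(NCc2cncs2)ccc1-c1cnco1` keeps the shared core and changes one group: 1,3-thiazol-5-yl in place of pyridin-4-yl on a saturated chain carbon bound to a nitrogen on an aromatic ring. Here, 1,3-thiazol-5-yl takes the place of pyridin-4-yl on a saturated chain carbon bound to a nitrogen on an aromatic ring. Among the measured compounds shown here, only one measured step bears on this place: a 6.4-fold higher number from compound 1 to compound 2 (0.80 log units; beyond the scatter), which exchanged 5-chlorothiophen-2-yl for pyridin-4-yl. For the measured compounds named here, the entering group, like the one in compound 1 at 53800 nM, is a sulfur-containing aromatic ring, so part of that step may be reversed. One step is thin evidence, and the range stays wide. The expected change is a drop in this assay, a 2.4-fold lower number from compound 2 to compound 3 (0.39 log units; beyond the scatter). For compound 3 the estimated value is 140000 nM, with an expected range of 45000 nM to 350000 nM.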

Compound 3, half-maximal cytotoxic concentration: 232000 nM
For compound 3 the middle estimate is 1.7-fold (0.22 log units) below the measured one; low and high end bracket the measured number.
By their numbers in this assay, from the lowest: compound 1; then compounds 3 and 2 (each within the scatter of the next).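

In this assay, a five-membered aromatic ring with 2 hetero atoms stands in for a six-membered one with 1 hetero atom, and the result is a 1.5-fold lower number from compound 2 to compound 3 (0.17 log units; within the scatter), so this exchange leaves no difference that can be told apart from ordinary repeat variation. A ring sulfur alone therefore does not bring back the low number of compound 1: 1,3-thiazol-5-yl also carries sulfur, yet the change in group gives a 4.3-fold higher number from compound 1 to compound 3 (0.63 log units; beyond the scatter). Nothing available explains either step.

Whether the chlorine or the thiophene ring sets compound 1 apart stays open: the compounds shown include no unsubstituted thiophen-2-yl group. They also leave unknown how a cyclohexyl ring or a longer alkyl chain would read at this place, on a saturated chain carbon bound to a nitrogen on an aromatic ring.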